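Swapping the Hydrated Trifluoromethyl Group for an Acetyl Group

The source may report more compounds than this note shows. Statements on the series, on what has been measured and on what is new or still open speak of the compounds shown alone.

Compound 1 `O=C(CCCCCCNC(=O)C(O)(O)C(F)(F)F)Nc1ccccc1` and compound 3 `O=C(CCCCNC(=O)C(O)(O)C(F)(F)F)Nc1ccccc1` both carry a 2,2,2-trifluoro-1,1-dihydroxyethyl group on a carbonyl carbon whose other neighbour is an amide-type nitrogen; the difference between the two cores is not broken down here. In a functional assay on HCT-116 cells (Homo sapiens) for inhibition, read by colorimetric assay, with a stated time of 3 days (on this read-out higher numbers stand for weaker inhibition and lower numbers for stronger inhibition), compound 1 gives 9140 nM. In this assay compound 3 gives 20300 nM, the highest of the two measured numbers, sitting beyond the usual scatter above compound 1.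

Compound 2 `CC(=O)C(=O)NCCCCCCC(=O)Nc1ccccc1` is compound 1 with acetyl in place of 2,2,2-trifluoro-1,1-dihydroxyethyl on a carbonyl carbon. In this assay compound 2 does not return a number but only a limit of the assay, > 100000 nM. The change brought an at least 10-fold higher number from compound 1 to compound 2 (1.03 log units; beyond the scatter), and because of the limit of > 100000 nM in this assay, at which 1 of the 3 values shown sits, only the lower bound of that step is known.

Compound 4 `CC(=O)C(=O)NCCCCC(=O)Nc1ccccc1` carries the same change on the core of compound 3: acetyl in place of 2,2,2-trifluoro-1,1-dihydroxyethyl on a carbonyl carbon. The surroundings of the place are the same in both cases. Compound 3 starts from the weaker number 20300 nM, so the same change is expected to carry compound 4 past the point where the assay can still report a number. Compound 4 is therefore expected to show a 15-fold higher number from compound 3 to compound 4 (1.17 log units; beyond the scatter) in this assay, resting on the step seen earlier, an at least 10-fold higher number from compound 1 to compound 2 (1.03 log units; beyond the scatter). The estimate for compound 4 in this assay is 300000 nM, within a range from 90000 nM to 1500000 nM, with a limit rather than a number the most likely outcome.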

Compound 4, half-maximal inhibitory concentration: > 100000 nM
Compound 4: no number, only a limit; the forecaster's own chance of this, stated with the estimate: 85%; the middle value lies beyond the limit too.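

Carried to the core of compound 3, the swap of 2,2,2-trifluoro-1,1-dihydroxyethyl for acetyl on a carbonyl carbon gives an at least 4.9-fold higher number from compound 3 to compound 4 (0.69 log units; beyond the scatter), so on both cores shown the change moves the number upward, which on this read-out means weaker inhibition. In this assay compound 4 gives > 100000 nM, which is a limit of the assay and not a number. The direction of the change therefore carries from one core to the other, but what this does not show is whether its size stays the same, since only lower bounds are available for the two steps: the same change on two cores in this assay, an at least 10-fold higher number (1.03 log units; beyond the scatter) from compound 1 to compound 2 and an at least 4.9-fold higher number (0.69 log units; beyond the scatter) from compound 3 to compound 4; the limit leaves it open whether they differ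

The compounds shown leave open what another group in the same place, on a carbonyl carbon whose other neighbour is an amide-type nitrogen, would give in this assay, for example a carboxylic acid or an amine-bearing group, and whether it would return a number rather than a limit. They also leave open whether the change would have the same direction on a core with a longer chain than those of compound 1 and compound 3.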